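The compounds below may be only part of what the source reports. "The series", "measured", "known", "first", "only" and "open" are said of these compounds alone.

The compounds share one core and differ in what sits on an oxygen on a saturated carbon. Compound 1 `CC(C)=CC[C@@H](OC(=O)c1ccoc1)C1=CC(=O)c2c(O)ccc(O)c2C1=O`, compound 2 `CCC(C)(O)CC(=O)O[C@H](CC=C(C)C)C1=CC(=O)c2c(O)ccc(O)c2C1=O` and compound 3 `CC(C)=CC[C@@H](OC[C@@H](C)O)C1=CC(=O)c2c(O)ccc(O)c2C1=O` have been tested in a functional assay on DU-145 cells (Homo sapiens) for cytotoxicity, read by MTT assay; a higher number here means a weaker inhibitor, a lower number a stronger inhibitor. For compound 1 the result is a limit of the assay, > 100000 nM (the limit of > 100000 nM in this assay, at which 1 of the 3 values shown sits). Compound 2 gives 16000 nM, and compound 3 gives 14300 nM. Compound 3 thus stands at the lower of the two numbers, yet the step of a 1.1-fold lower number from compound 2 to compound 3 (0.05 log units; within the scatter) is within the scatter, so the two compounds sit together. The steps beyond the scatter are an at least 6.2-fold lower number from compound 1 to compound 2 (0.79 log units; beyond the scatter) and an at least 6.9-fold lower number from compound 1 to compound 3 (0.84 log units; beyond the scatter), both away from the limit of compound 1.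

Compound 4 `CC(C)=CC[C@@H](OC[C@H](C)O)C1=CC(=O)c2c(O)ccc(O)c2C1=O` differs from compound 3 as follows: the two compounds have the same atoms and bonds and differ only in configuration as drawn: 1 of 2 stereo elements differ; a stereocentre at a saturated chain carbon is drawn R in compound 3 and S in compound 4. Among the compounds with values here, none of the measured steps changes configuration alone; each exchanges one group for another on the oxygen. Within the data shown here, no measured step therefore bears directly on this change, and the data give no guide to its direction. With atoms and bonds unchanged, compound 4 is expected to show a step of a 1.0-fold lower number from compound 3 to compound 4 (0.01 log units; within the scatter) that stays within the scatter. The estimate for compound 4 in this assay is 14000 nM, in a range from 5000 nM to 40000 nM.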

Compound 4, half-maximal inhibitory concentration: 24500 nM
Compound 4: middle estimate off by 1.8-fold (0.24 log units), on the low side; the measured number falls inside the stated range.
By their numbers in this assay, from the lowest: compounds 3, 2 and 4 (each within the scatter of the next). At a limit, above all of these: compound 1.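

In this assay, changing only the configuration of the saturated chain carbon in the 2-hydroxypropyl group gives a 1.7-fold higher number from compound 3 to compound 4 (0.23 log units; within the scatter), the first step here that tests configuration alone, and it does not separate the pair: the fact that compounds 3 and 4 differ only in the configuration as drawn

Exchanging the (2-hydroxy-2-methylbutyl)carbonyl group for this 2-hydroxypropyl form gives a 1.5-fold higher number from compound 2 to compound 4 (0.19 log units; within the scatter), so compounds 2, 3 and 4 sit together whichever of these groups or configurations is on the oxygen. Compound 1, with its (furan-3-yl)carbonyl group, stays apart from this set, with an at least 4.0-fold lower number from compound 1 to compound 4 (0.61 log units; beyond the scatter), a step read from a limit and so without a known upper size: the limit of > 100000 nM in this assay, at which 1 of the 4 values shown sits.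

The compounds shown leave open whether a plain propyl group, an amine, a carboxylic acid or a longer chain on this oxygen would stay with compounds 2, 3 and 4 or fall with compound 1. They also leave open what inverting the other stereocentre, drawn alike in compounds 3 and 4, would do in this assay.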